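The source may report more compounds than this note shows. Statements on the series, on what has been measured and on what is new or still open speak of the compounds shown alone.

Of the compounds shown here, three of one family have been tested in an ADME assay on cells (Mus musculus, strain Balb/c) for cytotoxicity, read by MTT assay, with a stated time of 48 h; a higher number here means that more compound is tolerated, a lower number that less compound is tolerated. Compound 1 `COc1ccc(C(/C=C/c2cccs2)=N/O)cc1` gives 10600 nM in this assay. Compound 2 `O/N=C(\C=C\c1cccs1)c1ccc(Br)cc1` gives 15400 nM in this assay, and compound 3 `Cc1ccc(C(/C=C/c2ccc(Br)cc2)=N/O)cc1` gives 34200 nM in this assay. Of the three, compound 3 is the one of which the most is tolerated, since its gap to compound 2 and its gap to compound 1 are both beyond the usual scatter.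

Compounds 2 and 1 differ in a single place, and the difference is methoxy in place of bromo on an aromatic carbon. That change made the step of a 1.5-fold lower number from compound 2 to compound 1 (0.16 log units; within the scatter), so the two values cannot be told apart with confidence.

Compound 4 `COc1ccc(/C=C/C(=N\O)c2ccc(C)cc2)cc1` has not yet been tested in this assay. It stands to compound 3 as compound 1 stands to compound 2: the difference is methoxy in place of bromo on an aromatic carbon. The two cores, that of compound 2 and that of compound 3, are themselves different, and how they differ is not broken down here. Because the earlier change gave only a 1.5-fold lower number from compound 2 to compound 1 (0.16 log units; within the scatter), the same change on the core of compound 3 is expected to give a step of about a 1.4-fold lower number from compound 3 to compound 4 (0.15 log units; within the scatter), so compound 4 is expected to land near the value of compound 3. The estimate for compound 4 in this assay is 24000 nM, expected to fall between 12000 nM and 48000 nM.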

Compound 4, half-maximal cytotoxic concentration: 117000 nM
Beside the measured number, compound 4's estimate is 4.9-fold (0.69 log units) below it, outside the stated range (above it).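

On the core of compound 3, putting methoxy in place of bromo on an aromatic carbon gave a 3.4-fold higher number from compound 3 to compound 4 (0.53 log units; beyond the scatter) in this assay, so here the change moves the number by more than repeated measurements would be expected to. Set beside the earlier pair, the same change did not carry over from one core to the other with the same size: the same change on two cores in this assay, a 1.5-fold lower number (0.16 log units; within the scatter) from compound 2 to compound 1 and a 3.4-fold higher number (0.53 log units; beyond the scatter) from compound 3 to compound 4, 5.0-fold (0.70 log units) apart, beyond the scatter of two such steps. This shows that, for these two pairs, a step measured on one core is a poor guide to the step on the other, but it does not show what about the cores is responsible, and two pairs give no rule for any further core in the series.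

The compounds shown leave open which part of the difference between the two cores goes with the different steps, since only one pair stands on each core. They also leave open how other groups on that aromatic carbon, such as an amine, a carboxylic acid or a longer chain like ethoxy, would behave on each of the two cores.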